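The source may hold more compounds than are shown below. What is called first, only, known or untested is meant among the compounds shown, and "the series" means these compounds.

For the measured compounds named here, compound 1 (`COc1ccc(Cc2nnc(NC(=O)/C(C#N)=C/c3ccccc3OS(=O)(=O)c3ccc(C)cc3)s2)cc1`) gives 21% in an ADME assay on HEK-293T cells (Homo sapiens) for inhibition, read by CCK-8 assay, with a stated time of 48 h, tested at 20 uM (on this read-out higher numbers stand for more inhibition of growth at the one concentration tested and lower numbers for less inhibition of growth), and so stands lower of the two compounds measured so far. The other is compound 2 (`COc1ccc(Cc2nnc(NC(=O)/C(C#N)=C/c3ccccc3OS(=O)(=O)c3ccc(Cl)cc3)s2)cc1`), which gives 34% in this assay and carries chloro in place of methyl on an aromatic carbon. Going by the values given here, that change goes with the only measured step, which is a number 13 percentage points higher from compound 1 to compound 2 (beyond the scatter) here.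

Compound 3 (`Cc1ccc(S(=O)(=O)Oc2ccccc2/C=C(\C#N)C(=O)Nc2nnc(Cc3ccc(F)cc3)s2)cc1`) keeps the methyl of compound 1 and differs in another place. It has fluoro in place of methoxy on an aromatic carbon, para to a large group, so that 4-methoxybenzyl becomes 4-fluorobenzyl (fluoro in place of methoxy on an aromatic carbon). Among the compounds with values here, no measured compound varies this place, so the step to compound 2 serves only as a rough gauge of how far a single change can move this read-out. A step of no more than that modest size is expected, with its direction left open by the data. The estimated step is a number 4 percentage points higher from compound 1 to compound 3 (within the scatter) in all.

Compound 3 is therefore expected at 25% (estimated range 10% to 42%).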

Compound 3, percent growth inhibition at one concentration: 16%
Compound 3: the middle estimate sits 9 percentage points above what was measured, and the stated range covers the measured number.
By their numbers in this assay, from the lowest: compounds 3 and 1 (each within the scatter of the next); then compound 2.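

In this assay, for the compounds shown here, the swap of 4-methoxybenzyl for 4-fluorobenzyl gives a number 5 percentage points lower from compound 1 to compound 3 (within the scatter), the first reading at this place, so with the methyl group kept, the read-out does not separate fluoro from methoxy on this aromatic carbon. Going by these compounds alone, this sets the place apart from the one varied earlier, where chloro in place of methyl gives a number 13 percentage points higher from compound 1 to compound 2 (beyond the scatter), the only step so far that lies beyond the scatter. No measurement is at hand that would explain either step.

The compounds shown leave open whether fluoro and methoxy would also read alike on the chloro background of compound 2, since the pair shown here carries the methyl group on both sides. Within the data shown here, they also leave open how far this place can move the read-out at all, since only two small groups stand there, and an amine, a carboxylic acid or a longer chain such as butoxy on the same aromatic carbon might give a quite different number.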